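The compounds below may be only part of what the source reports. "The series", "measured", "known", "first", "only" and "open" are said of these compounds alone.

Working notes on the series.

Among the measured compounds shown here, compound 2 `O=C(Nn1c(-c2ccccc2)nc2c(-c3ccc(Cl)cc3)n[nH]c2c1=O)c1ccccc1` stands second highest of the three numbers so far in a functional assay on DU-145 cells (Homo sapiens) for inhibition, read by MTT assay, with a stated time of 2 days (a lower number here means a stronger inhibitor of growth, a higher number a weaker inhibitor of growth), giving 20100 nM. Its nearest neighbour is compound 1 `COc1cccc(-c2nc3c(-c4ccc(Cl)cc4)n[nH]c3c(=O)n2NC(=O)c2ccccc2)c1`, which in this assay gives 17900 nM; the step of a 1.1-fold higher number from compound 1 to compound 2 (0.05 log units; within the scatter) is within the scatter, so the two are not distinguished. The furthest is compound 3 `O=C(Nn1c(CCc2ccccc2)nc2c(-c3ccc(Cl)cc3)n[nH]c2c1=O)c1ccccc1`, which gives 86700 nM; the steps of a 4.3-fold higher number from compound 2 to compound 3 (0.63 log units; beyond the scatter) and a 4.8-fold higher number from compound 1 to compound 3 (0.69 log units; beyond the scatter) are both beyond the scatter and modest in size.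

The next compound is compound 4 `CCCCc1nc2c(-c3ccc(Cl)cc3)n[nH]c2c(=O)n1NC(=O)c1ccccc1`. Relative to compound 2 the change is butyl in place of phenyl on an aromatic carbon. For the measured compounds named here, the measured step that bears on it is the one from compound 2 to compound 3, where a chain (phenethyl) replaced the phenyl at the same place and the number rose, a 4.3-fold higher number from compound 2 to compound 3 (0.63 log units; beyond the scatter). The step from compound 1 to compound 3 shows the same direction and similar size, a 4.8-fold higher number from compound 1 to compound 3 (0.69 log units; beyond the scatter). Butyl is likewise a chain without a ring entering in place of phenyl, so a modest rise in this assay is expected, of roughly the size seen with phenethyl; no measured step shows a chain at this place giving a lower number.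

For compound 4 the expected value in this assay is 60000 nM, with a range of 20000 nM to 180000 nM, which means an estimated step of a 3.0-fold higher number from compound 2 to compound 4 (0.47 log units; beyond the scatter).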

Compound 4, concentration for 50% growth inhibition: 29100 nM
Estimate against measurement, compound 4: 2.1-fold (0.31 log units) above, within the range that was stated.
By their numbers in this assay, from the lowest: compounds 1, 2 and 4 (each within the scatter of the next); then compound 3.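

Butyl in place of phenyl, on the aromatic carbon between two ring nitrogen atoms, does not separate the two compounds in this assay (a 1.4-fold higher number from compound 2 to compound 4 (0.16 log units; within the scatter)), and butyl in place of 3-methoxyphenyl likewise stays within the scatter (a 1.6-fold higher number from compound 1 to compound 4 (0.21 log units; within the scatter)), so losing the ring at this place does not by itself go with a higher number. The only rise at this place among the compounds shown belongs to phenethyl, and ethyl in place of the phenyl at the end of that chain brings the number down (a 3.0-fold lower number from compound 3 to compound 4 (0.47 log units; beyond the scatter)), which ties the rise to phenethyl rather than to chains in general. Nothing measured here explains these differences in the growth read-out.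

Two chains and two aryl groups at this place leave open whether a shorter chain such as methyl, a longer chain such as octyl, or a benzyl group would stay with compounds 1, 2 and 4 or move with compound 3. As far as these compounds go, an amine or a carboxylic acid on the end of the butyl chain also remains open, as does any change to the benzamido group.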